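Heteroaryl exchange on the shared core

The compounds below may be only part of what the source reports. "The series", "measured", "known", "first", "only" and "open" are said of these compounds alone.

Compound 1 `OC[C@H]1OC(n2cnc3c(-c4cc[nH]c4)ncnc32)[C@H](O)[C@@H]1O`: 1030 nM
Compound 2 `Cc1csc(-c2ncnc3c2ncn3C2O[C@H](CO)[C@@H](O)[C@H]2O)n1`: 6000 nM

In a functional assay on CCRF-CEM cells (Homo sapiens) for inhibition (a higher number here means a weaker inhibitor, a lower number a stronger inhibitor), compound 2 gives 6000 nM, the highest of the two numbers; nearest stands compound 1 with 1030 nM, and the step runs a 5.8-fold higher number from compound 1 to compound 2 (0.77 log units; beyond the scatter). Compound 3 `Cc1ccsc1-c1ncnc2c1ncn2C1O[C@H](CO)[C@@H](O)[C@H]1O` carries 3-methylthiophen-2-yl in place of 4-methyl-1,3-thiazol-2-yl on an aromatic carbon. Among the compounds with values here, no measured step covers this exchange directly. Within the data shown here, the only step in hand, a 5.8-fold higher number from compound 1 to compound 2 (0.77 log units; beyond the scatter), also swaps one five-membered heteroaryl for another and was modest, so a shift of at most that size in this assay is expected, direction uncertain. Compound 3 is estimated at 4000 nM, range 1000 nM to 15000 nM. This means an expected step of a 1.5-fold lower number from compound 2 to compound 3 (0.18 log units; within the scatter).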

Compound 3, half-maximal inhibitory concentration: 2500 nM
Estimate against measurement, compound 3: 1.6-fold (0.20 log units) above; the range from low to high includes it.
By their numbers in this assay, from the lowest: compound 1; then compound 3; then compound 2.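

In this assay, 3-methylthiophen-2-yl in place of 4-methyl-1,3-thiazol-2-yl gives a 2.4-fold lower number from compound 2 to compound 3 (0.38 log units; beyond the scatter), so a second hetero atom in the five-membered ring is not required at this position for activity in this range. The new group still falls short of 1H-pyrrol-3-yl, with a 2.4-fold higher number from compound 1 to compound 3 (0.39 log units; beyond the scatter), and compound 1 keeps the lowest number of the three. Nothing available explains either step. Open, from the compounds shown here alone, is whether the methyl group on the thiophene contributes to the step, and whether an amine or a phenyl ring on this aromatic carbon would give a lower number than compound 1.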